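A few compounds are considered here, and "the series" means these few. Any claim that something is new, unique, unknown or untested is made for them only; others in the source may bear on it.

Compound 1 `COc1ccc(-c2cc3c(OC)cc(OC)cc3n(C)c2=O)cc1` carries the shared core with a methyl on the ring nitrogen, and in a functional assay on LoVo cells (Homo sapiens) for cytotoxicity, read by colorimetric assay and MTT assay (on this read-out higher numbers stand for weaker inhibition and lower numbers for stronger inhibition), compound 1 gives 10000 nM. Compound 2 `CCOC(=O)Cn1c(=O)c(-c2ccc(OC)cc2)cc2c(OC)cc(OC)cc21` adds an ethoxycarbonyl on that chain carbon, and in this assay compound 2 gives 10000 nM, a step of no change at the digits printed from compound 1 to compound 2 (within the scatter), so compound 2 stands level with compound 1. Compound 3 `CCN(CC)C(=O)Cn1c(=O)c(-c2ccc(OC)cc2)cc2c(OC)cc(OC)cc21` differs from compound 2 by diethylamino in place of ethoxy on a carbonyl carbon. Because no change at the digits printed from compound 1 to compound 2 (within the scatter) lay within the scatter, the expected step is estimated as no change at the digits printed from compound 2 to compound 3 (within the scatter). Compound 3 is estimated at 10000 nM, between 5000 nM and 20000 nM.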

Compound 3, half-maximal inhibitory concentration: 10000 nM
Estimate against measurement, compound 3: no gap at the digits printed; low and high end bracket the measured number.
By their numbers in this assay, from the lowest: compounds 1, 2 and 3 (each within the scatter of the next).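

With diethylamino in place of ethoxy on the carbonyl carbon, this assay shows no change at the digits printed from compound 2 to compound 3 (within the scatter) and so does not separate these two groups. The diethylcarbamoyl group on the saturated chain carbon gives no change at the digits printed from compound 1 to compound 3 (within the scatter) as well, so neither group added at this chain carbon so far moves the number. No measured evidence here speaks to why the values stay level. Still open, on these data alone, is whether a carboxylic acid, a primary amine or a longer chain at this position would shift the reading.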